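Trading a two-halogen ring for a single chlorine

The source may report more compounds than this note shows. Statements on the series, on what has been measured and on what is new or still open speak of the compounds shown alone.

Compound 1 `COC(=O)C1=C(C)N=C(C)/C(=C(/O)OC)C1c1c(F)cccc1Cl` is the most potent of the three measured compounds in a functional assay (muscle tissue) with Cavia porcellus as the target (on this read-out lower numbers stand for an effect already at smaller amounts and higher numbers for an effect only at larger amounts of compound), where compound 1 gives 7.59 nM. Compound 3 `COC(=O)C1=C(C)N=C(C)/C(=C(\O)OC)C1c1cc(Cl)cc(Cl)c1` gives 93.3 nM in this assay, a higher number than compound 1, and compound 2 `COC(=O)C1=C(C)N=C(C)/C(=C(\O)OC)C1c1ccccc1N` gives 39800 nM, the highest number of the three. For the measured compounds named here, the only single-point step among them is a 430-fold lower number from compound 2 to compound 3 (2.63 log units; beyond the scatter), which shows that the aromatic group on that saturated ring carbon can shift the read-out very strongly.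

Compound 4 `COC(=O)C1=C(C)N=C(C)/C(=C(/O)OC)C1c1cccc(Cl)c1` differs from compound 1 in the same place: 3-chlorophenyl in place of 2-chloro-6-fluorophenyl on a saturated ring carbon. Going by the values given here, no measured step matches this exact exchange, so the expectation rests on the values of compound 1 and compound 3, whose 3,5-dichlorophenyl gives a number well above that of compound 1. Because compound 3 gives 93.3 nM with two chlorines on the ring, a ring with one chlorine is expected to land near it, somewhat above compound 1. The expected step is therefore a 20-fold higher number from compound 1 to compound 4 (1.30 log units; beyond the scatter), towards higher numbers. For compound 4 the estimate in this assay is 150 nM, with a likely range from 30 nM to 800 nM.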

Compound 4, half-maximal effective concentration: 15.9 nM
The estimate for compound 4 lay 9.4-fold (0.97 log units) above the measured number; measured number outside the range, below it.
By their numbers in this assay, from the lowest: compound 1; then compound 4; then compound 3; then compound 2.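

In this assay, replacing 2-chloro-6-fluorophenyl with 3-chlorophenyl on the saturated ring carbon gives a 2.1-fold higher number from compound 1 to compound 4 (0.32 log units; beyond the scatter), a modest step, though one that is still beyond the usual scatter. Beside the much larger a 430-fold lower number from compound 2 to compound 3 (2.63 log units; beyond the scatter), this shows that the position does not respond strongly to every change of aromatic ring: with one chlorine and no fluorine, compound 4 still stays at a low number, 15.9 nM, close to the lowest in the series. No accompanying measurement of any property of these groups is available, and the result therefore comes with no explanation.

This one exchange removes the fluorine and also changes where the chlorine sits on the ring, and the compounds shown cannot separate the contribution of each change. Going by these compounds, it remains open whether a phenyl ring carrying a single fluorine, a methoxy group, a trifluoromethyl group or a nitrile would also keep the number this low, and whether a cyclohexyl group could replace the aromatic ring altogether.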